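Chloro to hydrogen: expected shift in growth inhibition

The source may hold more compounds than are shown below. What is called first, only, known or untested is meant among the compounds shown, and "the series" means these compounds.

Two compounds of the series have been run in a functional assay on CCRF-CEM cells (Homo sapiens) for antiproliferative activity, read by sulforhodamine B assay, with a stated time of 48 h; on this read-out higher numbers stand for weaker inhibition of growth and lower numbers for stronger inhibition of growth. Compound 1 `COc1ccc(OC)c(/C=C/c2nnc(Nc3ccc(Cl)cc3)o2)c1` gives > 100000 nM in this assay , which is a limit of the assay and not a number, namely (the limit of > 100000 nM in this assay, at which 1 of the 2 values shown sits). Going by the values given here, compound 2 `COc1ccc(OC)c(/C=C/C(=O)N/N=C/c2ccc(Cl)cc2)c1` gives 228 nM in this assay , the only true number in the set. Compound 3 `COc1ccc(OC)c(/C=C/C(=O)N/N=C/c2ccccc2)c1` has not yet been measured. It differs from compound 2 by hydrogen in place of chloro on an aromatic carbon: the chloro on the six-membered aromatic ring of carbon only, para to a large group, is replaced by hydrogen. Among the compounds with values here, no measured pair in the set covers this change, so its size must be judged without a precedent. Removal of the chloro is expected to cost some potency, a step somewhat beyond the usual scatter but not large, so compound 3 is estimated at 550 nM, with a plausible range from 150 nM to 2500 nM. The expected step of a 2.4-fold higher number from compound 2 to compound 3 (0.38 log units; beyond the scatter) is a modest weakening of growth inhibition.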

Compound 3, concentration for 50% growth inhibition: 3970 nM
For compound 3 the middle estimate is 7.2-fold (0.86 log units) below the measured one; measured number above the stated range.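

In this assay the change from 4-chlorophenyl to phenyl gives a 17-fold higher number from compound 2 to compound 3 (1.24 log units; beyond the scatter) and so counts as a large step, the first readable measure of what this position contributes. Growth inhibition in this pair therefore depends strongly on whether the six-membered aromatic ring of carbon only bears chloro or hydrogen at the place para to a large group, with compound 2 clearly the stronger of the two; this rests on a single pair and holds for the shared core of compound 2 and compound 3 only. Nothing shown here gives a reason for the size of this step.

The compounds shown leave open whether the effect belongs to chloro itself or would also appear with fluoro, bromo, methoxy or an amine at the same place. Also open is whether the same exchange would carry a step of similar size on the core of compound 1, since no pair on that core is shown.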